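From Isopropyl to Cyclohexyl on a Shared Core

The source may report more compounds than this note shows. Statements on the series, on what has been measured and on what is new or still open speak of the compounds shown alone.

Of the compounds shown here, three with the same core have so far been tested in an assay on HL-60 cells for agonist activity at N-formyl peptide receptor 3 (Homo sapiens), read by calcium flux; on this read-out higher numbers stand for an effect only at larger amounts of compound and lower numbers for an effect already at smaller amounts. Compound 1 `COc1cccc(Cc2ccnn(CC(=O)Nc3ccc(Br)cc3)c2=O)c1` gives 14600 nM. Among the measured compounds shown here, compound 3 `COc1cccc(Cc2cc(C(C)C)nn(CC(=O)Nc3ccc(Br)cc3)c2=O)c1` gives 17400 nM in this assay, the highest of the two numbers known, with compound 1 nearest to it. Compound 2 `CCc1cc(Cc2cccc(OC)c2)c(=O)n(CC(=O)Nc2ccc(I)cc2)n1` reaches only a limit of the assay, > 50000 nM, so no number stands behind it (the limit of > 50000 nM in this assay, at which 1 of the 3 values shown sits).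

Compound 4 `COc1cccc(Cc2cc(C3CCCCC3)nn(CC(=O)Nc3ccc(Br)cc3)c2=O)c1` has not yet been measured. It differs from compound 3 in one place: cyclohexyl in place of isopropyl on an aromatic carbon. For the measured compounds named here, only one measured step touches this same position: the change a 1.2-fold higher number from compound 1 to compound 3 (0.08 log units; within the scatter), which stayed within the scatter. Moving from isopropyl to cyclohexyl at that spot is a further enlargement, and the one step available gives no sign of a direction. Compound 4 is therefore expected to give about 20000 nM in this assay, somewhere between 8000 nM and 50000 nM. That expected result would mean a step of a 1.1-fold higher number from compound 3 to compound 4 (0.06 log units; within the scatter), nothing beyond the scatter.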

Compound 4, half-maximal effective concentration: > 50000 nM
Compound 4: no number, only a limit; the forecaster's own chance of this, stated with the estimate: 25%; middle value at least 2.5-fold (0.39 log units) from the limit.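

Among the compounds shown here, until now the only step at this position, a 1.2-fold higher number from compound 1 to compound 3 (0.08 log units; within the scatter), stayed within the scatter, so the position seemed to make little difference to the read-out. Cyclohexyl changes that picture, with an at least 2.8-fold higher number from compound 3 to compound 4 (0.45 log units; beyond the scatter) and an at least 3.4-fold higher number from compound 1 to compound 4 (0.53 log units; beyond the scatter), so in this assay the group on this aromatic carbon can matter after all. Compound 4 gives only a limit of the assay, not a number, so the true size of both steps stays unknown: the limit of > 50000 nM in this assay, at which 2 of the 4 values shown sit.

Isopropyl and cyclohexyl differ both in their number of carbons and in the presence of a ring, and these compounds do not separate those two changes. A cyclopropyl or tert-butyl group, or an amine, at the same position could show how much change this spot allows.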